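Notes on a piperidinyl swap carried onto a second core

This account rests on a few compounds, and the source may have more. Where it says the series, first, only, none or still open, it means among the compounds named here.

Compound 1 `COc1ccc(/C=C/c2nc(NCCN(C(C)C)C(C)C)c3ccccc3n2)cc1OC` and compound 2 `COc1ccc(/C=C/c2nc(NCCN3CCCCC3)c3ccccc3n2)cc1OC` share one core and differ only in the amine at the far end of the ethyl chain. In a functional assay on PC-3 cells (Homo sapiens) for cytotoxicity, read by MTT assay, with stated times of 48 h and 4 h (on this read-out higher numbers stand for weaker inhibition and lower numbers for stronger inhibition), compound 1 gives 20300 nM, while compound 2 gives 78500 nM. The change between them is piperidin-1-yl in place of diisopropylamino on a saturated chain carbon, two bonds along the chain from a nitrogen on an aromatic ring, and it produced a 3.9-fold higher number from compound 1 to compound 2 (0.59 log units; beyond the scatter).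

Compound 3 `CC(C)N(CCNc1nc(/C=C/c2ccc([N+](=O)[O-])cc2)nc2ccccc12)C(C)C` keeps the amine of compound 1 but carries another aryl group on the double bond: the difference between the two cores is 4-nitrophenyl in place of 3,4-dimethoxyphenyl on a double-bonded chain carbon bound to a double-bonded chain carbon. In this assay compound 3 reaches only the limit of the measurement, > 100000 nM, which is a limit and not a number (the limit of > 100000 nM in this assay, at which 1 of the 3 values shown sits). The step of an at least 4.9-fold higher number from compound 1 to compound 3 (0.69 log units; beyond the scatter) is therefore a floor rather than a settled size.

Compound 4 `O=[N+]([O-])c1ccc(/C=C/c2nc(NCCN3CCCCC3)c3ccccc3n2)cc1` is not yet measured in this assay. It stands to compound 3 exactly as compound 2 stands to compound 1, through (piperidin-1-yl in place of diisopropylamino on a saturated chain carbon, two bonds along the chain from a nitrogen on an aromatic ring), the same change at the same place. The earlier instance of this change gave a 3.9-fold higher number from compound 1 to compound 2 (0.59 log units; beyond the scatter), and compound 3 already sits at a limit, so the expected step is a step that the limit leaves unreadable from compound 3 to compound 4. Compound 4 is expected to give about 300000 nM. For compound 4 the expected range runs from 100000 nM to 1000000 nM, with a high chance that this assay again reports only a limit.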

Compound 4, half-maximal inhibitory concentration: 25600 nM
The estimate for compound 4 lay 12-fold (1.07 log units) above the measured number, outside the stated range (below it).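

In this assay, the swap to piperidin-1-yl on the core of compound 3 gives an at least 3.9-fold lower number from compound 3 to compound 4 (0.59 log units; beyond the scatter), the opposite direction to that seen on the core of compound 1, so the change did not carry over from one core to the other: the same change on two cores in this assay, a 3.9-fold higher number (0.59 log units; beyond the scatter) from compound 1 to compound 2 and an at least 3.9-fold lower number (0.59 log units; beyond the scatter) from compound 3 to compound 4, at least 15-fold (1.17 log units) apart, beyond the scatter of two such steps

Read the other way round the same set of four compounds, the 4-nitrophenyl change gives a 3.1-fold lower number from compound 2 to compound 4 (0.49 log units; beyond the scatter) on the piperidin-1-yl side, which also runs against its course on the diisopropylamino side: the same change on two cores in this assay, an at least 4.9-fold higher number (0.69 log units; beyond the scatter) from compound 1 to compound 3 and a 3.1-fold lower number (0.49 log units; beyond the scatter) from compound 2 to compound 4, at least 15-fold (1.17 log units) apart, beyond the scatter of two such steps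

In these four compounds, then, the outcome of each change depends on the group held at the other place, but this rests on a single set of four and does not give the true size of the reversal, because the value of compound 3 is a limit and not a number: the limit of > 100000 nM in this assay, at which 1 of the 4 values shown sits.

As far as these compounds go, it remains open whether the reversal would hold with other aryl groups on the double bond, such as 4-chlorophenyl or 4-methoxyphenyl. Also open, from the compounds shown here alone, is how other amines at the end of the ethyl chain, such as morpholin-4-yl or pyrrolidin-1-yl, or a longer chain such as propyl, would behave on the two cores.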